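Swapping isopropyl for hydroxyethyl on the amide-bearing carbon

The compounds below may be only part of what the source reports. "The series", "measured", "known", "first", "only" and "open" are said of these compounds alone.

Within the data shown here, compound 2 `COC(=O)[C@@H](NC(=O)c1cnc2ccccc2c1Cl)C(C)C` is the only compound with a real number in an ADME assay on CCRF-CEM cells (Homo sapiens) for cytotoxicity; on this read-out lower numbers stand for higher toxicity in this test and higher numbers for lower toxicity in this test; in that test compound 2 gives 17.6 uM. Compound 1 `COC(=O)CNC(=O)c1cnc2ccccc2c1Cl` reaches only a limit of the test, > 100 uM, and so has no number of its own. Among the measured compounds shown here, the single measured step is an at least 5.6-fold lower number from compound 1 to compound 2 (0.75 log units; beyond the scatter), so compound 2 stands at the low end of what is known. Compound 3 `COC(=O)[C@@H](NC(=O)c1cnc2ccccc2c1Cl)[C@@H](C)O` has not yet been measured. It differs from compound 2 by 1-hydroxyethyl in place of isopropyl on a saturated chain carbon bound to an amide-type nitrogen and a carbonyl carbon. No measured step swaps one small chain for another that carries a hydroxyl; the one step known concerns putting a chain where hydrogen was, and it bears on this change only loosely, as shown by the limit of > 100 uM in this assay, at which 1 of the 2 values shown sits. The expectation is therefore for a modest shift at most, its direction open but leaning toward a higher number, which for compound 3 means an expected step of a 2.3-fold higher number from compound 2 to compound 3 (0.36 log units; beyond the scatter). Compound 3 is expected to give about 40 uM, with a range from 12 uM to 150 uM.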

Compound 3, half-maximal toxic concentration: > 100 uM
Compound 3 was reported as a limit; the forecaster's own chance of this, stated with the estimate: 35%; middle value at least 2.5-fold (0.39 log units) away from the limit.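

In this assay, the saturated chain carbon bound to an amide-type nitrogen and a carbonyl carbon responds to what the chain carries, and not merely to whether a chain is there: 1-hydroxyethyl in place of isopropyl gives an at least 5.6-fold higher number from compound 2 to compound 3 (0.75 log units; beyond the scatter). The two groups have the same count of heavy atoms, and the entering one brings an oxygen, a hydrogen-bond donor and a hydrogen-bond acceptor that isopropyl lacks. Compound 3 reaches only a limit of the test, > 100 uM, so a chain at this place does not by itself bring the number down to the level of compound 2.

Going by these compounds, the step from compound 1 to compound 3 cannot be read, so how far hydrogen and 1-hydroxyethyl stand apart remains unknown, because both values are limits: the limit of > 100 uM in this assay, at which 2 of the 3 values shown sit. Whether the low number of compound 2 belongs to isopropyl alone also stays open, and an amine or a carboxylic acid on this carbon, or a longer chain without a hydroxyl, would show how far that reading holds.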